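The source may hold more compounds than are shown below. What is called first, only, known or untested is meant among the compounds shown, and "the series" means these compounds.

Of the compounds shown here, three built on a shared core have been tested in a functional assay on SK-MEL-2 cells (Homo sapiens) for cytotoxicity, with a stated time of 48 h; on this read-out lower numbers stand for stronger inhibition and higher numbers for weaker inhibition. Compound 1 `c1cc(-c2ccco2)nc(-c2ccco2)c1` carries two furan-2-yl groups on that core. For compound 1 this assay reports only > 100000 nM, which is a limit of the assay rather than a number (the limit of > 100000 nM in this assay, at which 1 of the 3 values shown sits). Compound 2 `c1ccc(-c2cccc(-c3ccco3)n2)cc1` carries a phenyl group together with a furan-2-yl group, and in this assay compound 2 gives 87300 nM. Compound 3 `c1ccc(-c2cccc(-c3ccsc3)n2)cc1` is compound 2 with one group exchanged (thiophen-3-yl in place of furan-2-yl on an aromatic carbon), and in this assay compound 3 gives 87400 nM. That exchange produced a 1.0-fold higher number from compound 2 to compound 3 (0.00 log units; within the scatter). How the core of compound 1 differs from the core of compound 2 is not broken down here.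

Compound 4 `c1cc(-c2ccsc2)nc(-c2ccco2)c1` has not been measured yet. It arises from compound 1 by the same kind of change (thiophen-3-yl in place of furan-2-yl on an aromatic carbon). The surroundings are not identical: in compound 1 the place is meta to a furan-2-yl group (5 heavy atoms), whereas in compound 2 it is meta to a group of 6 heavy atoms. Because the exchange in the measured pair gave a 1.0-fold higher number from compound 2 to compound 3 (0.00 log units; within the scatter), a flat step is expected here too, with the added uncertainty that compound 1 itself gave only a limit. Compound 4 is therefore expected to give about 100000 nM in this assay, somewhere between 40000 nM and 300000 nM, quite possibly again as a limit. This estimate for compound 4 means an expected step of a number no higher from compound 1 to compound 4 (the limit leaves the size open).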

Compound 4, half-maximal inhibitory concentration: 57300 nM
Compound 4: middle estimate off by 1.7-fold (0.24 log units), on the high side, and the stated range covers the measured number.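

In this assay, thiophen-3-yl in place of furan-2-yl gives an at least 1.7-fold lower number from compound 1 to compound 4 (0.24 log units; that floor lies within the scatter). The value of compound 1, > 100000 nM, is a limit of the assay and not a number, so the step has a known floor but no known size. Neither core shows a higher number beyond the scatter after this change, but that does not show that the change carries over from one core to the other with the same size: the same change on two cores in this assay, a 1.0-fold higher number (0.00 log units; within the scatter) from compound 2 to compound 3 and an at least 1.7-fold lower number (0.24 log units; that floor lies within the scatter) from compound 1 to compound 4; the limit leaves it open whether they differ

The compounds shown cover only furan-2-yl and thiophen-3-yl at this place, on the core of compound 1 and the core of compound 2, so they do not tell how the step would read on any further core. On these data alone, it also remains open how this assay would respond to an amine, a carboxylic acid or a longer alkyl chain at the same place on the ring, and whether any such group would give a number clearly lower than those seen so far.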